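Cytotoxicity notes on the shared core: compound 1 to compound 4

The source may hold more compounds than are shown below. What is called first, only, known or untested is meant among the compounds shown, and "the series" means these compounds.

Three compounds of the series have been run in an ADME assay on PC-3 cells (Homo sapiens) for cytotoxicity, read by WST assay, tested at 100 uM; on this read-out lower numbers stand for less inhibition and higher numbers for more inhibition at the one concentration tested (going by the name of the read-out). Compound 1 `Cc1cccc(C(=O)N2CCCC(C(=O)Nc3ccc(Cl)cc3)C2)c1` gives 0% in this assay. Compound 2 `O=C(Nc1cccc(Oc2ccccc2)c1)C1CCCN(C(=O)c2cccc(-c3ccco3)c2)C1` gives 0%, and compound 3 `Cn1cnnc1-c1cccc(NC(=O)C2CCCN(C(=O)c3cc(C(F)(F)F)cc(C(F)(F)F)c3)C2)c1` gives 0%. Compound 1 therefore stands level with compound 2 and compound 3 at the digits shown; the nearest, compound 2, and the furthest, compound 3, both show no change from it within the scatter. Within the data shown here, no two of the measured compounds differ in a single place, so no measured step between them is available.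

Compound 4 `COCc1cccc(C(=O)N2CCCC(C(=O)Nc3ccc(Cl)cc3)C2)c1` is the next compound to be measured in this assay. It differs from compound 1 in one place: methoxy in place of hydrogen on a saturated chain carbon bound to an aromatic carbon. Cut one bond further out, the change reads methyl to methoxymethyl, or 3-methylphenyl to 3-(methoxymethyl)phenyl.

Among the measured compounds shown here, with no measured step to lean on, the expectation rests on the flat run of compound 1, compound 2 and compound 3, none of which shows any inhibition. The step of a number 1 percentage points higher from compound 1 to compound 4 (within the scatter) is expected to be none beyond the scatter, in neither direction. Compound 4 is estimated at 1%, with a range from -6% to 12%.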

Compound 4, a percentage reported as inhibition, at one concentration (the size of the read-out at that concentration, not a potency): 0%
For compound 4 the middle estimate is 1 percentage points above the measured one; the measured number falls inside the stated range.
By their numbers in this assay, from the lowest: compounds 1, 2, 3 and 4 (each within the scatter of the next).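

In this assay the series now has its first step in a single place: methoxy in place of hydrogen on a saturated chain carbon bound to an aromatic carbon brings no change at the digits printed from compound 1 to compound 4 (within the scatter) and leaves the read-out flat. Read one bond further out, 3-methylphenyl to 3-(methoxymethyl)phenyl on the core of compound 1 is therefore a change that, at this one position and this one concentration, adds no measurable inhibition, with compound 4 at 0% in this assay and the anilide side untouched. No supporting measurement accompanies this step, and the result carries no explanation.

On these data alone, whether this flat read-out holds for other groups at the same carbon stays open, for example an amine, a carboxylic acid or a longer chain in place of the methoxy. Among these compounds, also open is whether any change on the shared core moves the read-out beyond the scatter, since the single step available so far is this one and it says nothing about the amide side of the molecule.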